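Working notes: trifluoromethyl position change, compound 1 to compound 3

The source may hold more compounds than are shown below. What is called first, only, known or untested is meant among the compounds shown, and "the series" means these compounds.

In a functional assay on HeLa cells (Homo sapiens) for inhibition, read by MTT assay, with a stated time of 72 h (a lower number here means a stronger inhibitor, a higher number a weaker inhibitor), compound 1 `CN(C(=O)NC(=O)c1ccc(C(F)(F)F)cc1)c1nc(C(F)(F)F)c(C(=O)N/N=C/c2cccc(C(F)(F)F)c2)s1` gives 6.2 ug/mL. Going by the values given here, its only measured neighbour is compound 2 `CN(C(=O)NC(=O)c1ccc([N+](=O)[O-])cc1)c1nc(C(F)(F)F)c(C(=O)N/N=C/c2cccc(C(F)(F)F)c2)s1`, which gives 4.12 ug/mL in this assay; the step of a 1.5-fold lower number from compound 1 to compound 2 (0.18 log units; within the scatter) is the sole comparison at hand, and it concerns the other end of the molecule, away from the carbon with the double bond to nitrogen. Compound 3 `CN(C(=O)NC(=O)c1ccc(C(F)(F)F)cc1)c1nc(C(F)(F)F)c(C(=O)N/N=C/c2ccccc2C(F)(F)F)s1` has not been measured. It differs from compound 1 in one place: 2-(trifluoromethyl)phenyl in place of 3-(trifluoromethyl)phenyl on a carbon with a double bond to nitrogen. Among the compounds with values here, no measured step touches this position, so the expectation rests only on the observation that the single change made so far stayed within the scatter. The step of no change at the digits printed from compound 1 to compound 3 (within the scatter) is therefore expected to stay within the scatter, with no direction claimed. The estimate for compound 3 in this assay is 6.2 ug/mL, with a range from 2.5 ug/mL to 15 ug/mL.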

Compound 3, half-maximal inhibitory concentration: 3.76 ug/mL
Compound 3: the middle estimate sits 1.6-fold (0.22 log units) above what was measured; low and high end bracket the measured number.
By their numbers in this assay, from the lowest: compounds 3, 2 and 1 (each within the scatter of the next).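

Working notes, continued. Going by these compounds alone, the swap of 3-(trifluoromethyl)phenyl for 2-(trifluoromethyl)phenyl on the carbon with a double bond to nitrogen is the first measured change at this end of the molecule, and in this assay it gives a 1.6-fold lower number from compound 1 to compound 3 (0.22 log units; within the scatter). The two placements of the trifluoromethyl group therefore cannot be told apart in this assay, so this position accepts the swap without a step beyond the scatter. No supporting data bear on this result, and nothing here offers an explanation for it.

Going by these compounds, it remains open whether an amine, a carboxylic acid or a methoxy group in place of trifluoromethyl on this phenyl ring would also stay within the scatter. Also open, on these data alone, is whether the nitro group of compound 2 and the 2-(trifluoromethyl)phenyl group of compound 3 would behave independently when placed in one molecule.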